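Replacing the furan-2-yl group of compound 2

This account rests on a few compounds, and the source may have more. Where it says the series, first, only, none or still open, it means among the compounds named here.

Measured in a functional assay on PC-3 cells (Homo sapiens) for inhibition, read by colorimetric assay and sulforhodamine B assay, with a stated time of 48 h; a higher number here means a weaker inhibitor of growth, a lower number a stronger inhibitor of growth:
compound 1 `CCCCCCCCCCCC[C@@H](O)[C@H]1CC[C@H]([C@H](O)CCCCCCCCCCNC(=O)c2cccs2)O1`: 2290 nM
compound 2 `CCCCCCCCCCCC[C@@H](O)[C@H]1CC[C@H]([C@H](O)CCCCCCCCCCNC(=O)c2ccco2)O1`: 100000 nM
compound 3 `CCCCCCCCCCCC[C@@H](O)[C@H]1CC[C@H]([C@H](O)CCCCCCCCCCNC(=O)c2cncs2)O1`: 100000 nM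

Compound 2 stands level with compound 3, together the highest of the three numbers. Compound 4 `CCCCCCCCCCCC[C@@H](O)[C@H]1CC[C@H]([C@H](O)CCCCCCCCCCNC(=O)c2ccnn2C)O1` carries 1-methyl-1H-pyrazol-5-yl in place of furan-2-yl on a carbonyl carbon. Leaving thiophen-2-yl gave a 44-fold higher number from compound 1 to compound 2 (1.64 log units; beyond the scatter) and a 44-fold higher number from compound 1 to compound 3 (1.64 log units; beyond the scatter), both large. Compound 4 also lacks thiophen-2-yl, and the closest guide is no change at the digits printed from compound 2 to compound 3 (within the scatter), so no step beyond the scatter is expected in this assay. The estimated step is a 1.7-fold lower number from compound 2 to compound 4 (0.22 log units; within the scatter). For compound 4 the estimated value is 60000 nM, with an expected range of 6000 nM to 100000 nM.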

Compound 4, concentration for 50% growth inhibition: 18200 nM
Estimate against measurement, compound 4: 3.3-fold (0.52 log units) above; the range from low to high includes it.
By their numbers in this assay, from the lowest: compound 1; then compound 4; then compounds 2 and 3 (each within the scatter of the next).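

In this assay, the groups that replace thiophen-2-yl on this carbonyl carbon turn out not to be equivalent: 1-methyl-1H-pyrazol-5-yl gives a 5.5-fold lower number from compound 2 to compound 4 (0.74 log units; beyond the scatter) and a 5.5-fold lower number from compound 3 to compound 4 (0.74 log units; beyond the scatter). Even so, it does not restore the level of thiophen-2-yl, with a 7.9-fold higher number from compound 1 to compound 4 (0.90 log units; beyond the scatter). No measurement at hand accounts for this order.

Whether the methyl on the pyrazole contributes stays open, as the unmethylated 1H-pyrazol-5-yl group is not among the compounds shown. On these data alone, how a phenyl ring would compare at this position also remains unknown.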